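A few compounds are considered here, and "the series" means these few. Any claim that something is new, unique, unknown or untested is made for them only; others in the source may bear on it.

Compound 2, drawn as `CCN(c1ccc(C#N)c(Cl)c1)c1cc(-c2cn[nH]c2)ccc1C`, carries a 1H-pyrazol-4-yl group at a position where compound 1, drawn as `CCN(c1ccc(C#N)c(Cl)c1)c1cc(-c2ccoc2)ccc1C`, carries a furan ring. In a functional assay on VCaP cells (Homo sapiens) for antiproliferative activity, read by CCK-8 assay, with a stated time of 6 days (a lower number here means a stronger inhibitor, a higher number a weaker inhibitor), compound 1 gives 4010 nM. For compound 2 the result in this assay is recorded as "not determined" (no result reported), so compound 2 stands without a number among the values shown. Compound 3, drawn as `Cc1noc(C)c1-c1cccc2c1CCCN2c1ccc(C#N)c(C(F)(F)F)c1`, rests on a different core. In this assay compound 3 gives only a limit of the assay, > 30000 nM. That limit is the point described by the limit of > 30000 nM in this assay, at which 1 of the 3 values shown sits.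

Compound 4, drawn as `CCN(c1ccc(C#N)c(Cl)c1)c1cc(C2=CCCCC2)ccc1C`, is reached from compound 2 by the change (cyclohex-1-en-1-yl in place of 1H-pyrazol-4-yl on an aromatic carbon). The data hold no measured step that mirrors this change, and compound 2 itself has no number, so the size of the step cannot be read from anything shown. Among the measured compounds shown here, compound 1, the one measured neighbour on the shared core, is the only anchor. Compound 4 is expected to give about 5000 nM in this assay, in a range from 1500 nM to 20000 nM, with no direction beyond the scatter claimed relative to compound 2.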

Compound 4, half-maximal inhibitory concentration: 20000 nM
The estimate for compound 4 lay 4.0-fold (0.60 log units) below the measured number, within the range that was stated.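

Setting cyclohex-1-en-1-yl in place of furan-3-yl on the shared core gives, in this assay, a 5.0-fold higher number from compound 1 to compound 4 (0.70 log units; beyond the scatter). Among the compounds shown here, this is the first readable step at this position, and it shows that a change of ring here moves the result beyond the scatter, towards a weaker inhibitor. The number for compound 4 is still a measured value and not a limit, and only compound 3, on a different core, reaches one: the limit of > 30000 nM in this assay, at which 1 of the 4 values shown sits.

From the compounds shown here alone, compound 2 has no number, so the step from it to compound 4 cannot be read, and where the 1H-pyrazol-4-yl group stands relative to the other two rings remains unknown. Going by these compounds, how a phenyl ring, an amine or a carboxylic acid at this position would compare with furan-3-yl also remains open.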